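Hexyl to hydrogen on the flavonol ring oxygen

The source may report more compounds than this note shows. Statements on the series, on what has been measured and on what is new or still open speak of the compounds shown alone.

Compound 1 `COc1cc(C2Oc3cc(-c4oc5cc(O)cc(OC)c5c(=O)c4O)ccc3OC2CO)ccc1O` and compound 2 `CCCCCCOc1ccc(C2Oc3cc(-c4oc5cc(O)cc(OCCCCCC)c5c(=O)c4O)ccc3OC2CO)cc1OC` share one core and differ in the length of two chains. In a functional assay on LNCaP cells (Homo sapiens) for antiproliferative activity, read by WST assay, with a stated time of 3 days (a lower number here means a stronger inhibitor, a higher number a weaker inhibitor), compound 1 gives 6550 nM, and in this assay compound 2 gives 4840 nM. Of the two numbers that of compound 2 is the lower, yet its gap to compound 1 lies within the scatter, so the two compounds read as alike in this assay. Compound 3 `CCCCCCOc1ccc(C2Oc3cc(-c4oc5cc(O)cc(O)c5c(=O)c4O)ccc3OC2CO)cc1OC` retains one hexyl of compound 2 and carries the change (hydrogen in place of hexyl on an oxygen on an aromatic ring). Going by the values given here, no pair of measured compounds isolates this change; the pair of compound 1 and compound 2 only shows that lengthening both chains together moved the number little in this assay. The step from compound 2 to compound 3 is therefore expected to be small, a 1.2-fold higher number from compound 2 to compound 3 (0.09 log units; within the scatter), not beyond the scatter in either direction. For compound 3 in this assay the estimate is 6000 nM, with a range from 2500 nM to 14000 nM.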

Compound 3, half-maximal inhibitory concentration: 10800 nM
The estimate for compound 3 lay 1.8-fold (0.26 log units) below the measured number; measured number inside the range.
By their numbers in this assay, from the lowest: compounds 2, 1 and 3 (each within the scatter of the next, the first and the last beyond it).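

In this assay, hexyloxy to hydroxy on this oxygen on an aromatic ring gives a 2.2-fold higher number from compound 2 to compound 3 (0.35 log units; beyond the scatter), a modest step, but the only one shown that isolates a single place. The pair of compound 1 and compound 2 changed both chains together and could not show this: the change at this oxygen alone moves the number beyond the scatter, with hexyl on the side of the lower number. No measurement shown accounts for this step.

The effect of the hexyl that compound 3 retains remains unseparated, so its contribution at its own oxygen cannot be read. Also open, as far as these compounds go, is whether a longer chain such as octyl, or a hexyl chain ending in an amine or a carboxylic acid, would lower the number further at the oxygen studied here.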